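The source may hold more compounds than are shown below. What is called first, only, known or untested is meant among the compounds shown, and "the series" means these compounds.

In a functional assay, read by spectrophotometry, with a stated time of 5 min (on this read-out lower numbers stand for stronger inhibition and higher numbers for weaker inhibition), compound 1 `O=c1[nH]c2ccccc2cc1/C=N/O` gives 463000 nM, compound 2 `O=c1[nH]c2ccccc2cc1/C=N/c1ccc(O)cc1` gives 306000 nM and compound 3 `Cc1ccc2[nH]c(=O)c(/C=N/O)cc2c1` gives 389000 nM. Compound 1 therefore stands level with both, since the three numbers lie within the scatter of one another. Compound 4 `N/N=C/c1cc2ccccc2[nH]c1=O` has amino in place of hydroxy on a double-bonded nitrogen. Within the data shown here, the only measured step, a 1.2-fold lower number from compound 1 to compound 3 (0.08 log units; within the scatter), is a methyl in place of hydrogen on an aromatic carbon, so it bears only indirectly on this change. Compound 2 also carries a different group on that nitrogen and stays within the scatter of compound 1. No step beyond the scatter is expected in this assay, and the estimated step is a 1.2-fold lower number from compound 1 to compound 4 (0.06 log units; within the scatter). Compound 4 is expected at 400000 nM, with an estimated range of 150000 nM to 900000 nM.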

Compound 4, half-maximal inhibitory concentration: 184000 nM
For compound 4 the middle estimate is 2.2-fold (0.34 log units) above the measured one; the measured number falls inside the stated range.
By their numbers in this assay, from the lowest: compounds 4, 2, 3 and 1 (each within the scatter of the next, the first and the last beyond it).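

Among these compounds, on the double-bonded nitrogen, amino in place of hydroxy gives the first step beyond the scatter in this assay: a 2.5-fold lower number from compound 1 to compound 4 (0.40 log units; beyond the scatter), modest in size. A change of one heavy atom at this place is therefore enough to move the number, whereas the methyl step elsewhere on the core, a 1.2-fold lower number from compound 1 to compound 3 (0.08 log units; within the scatter), stayed within the scatter. Nothing available explains this step.

Open, on these data alone, is how methoxy or dimethylamino on that nitrogen would read. Also open, as far as these compounds go, is whether amino and the methyl of compound 3 would combine.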